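Swapping Ethoxy for Chloro in a Weak Inhibitor Series

The compounds below may be only part of what the source reports. "The series", "measured", "known", "first", "only" and "open" are said of these compounds alone.

Compound 1 `CC(C)n1c(S)nnc1Sc1nnc(-c2ccccc2)n1-c1ccccc1` and compound 2 `CCOc1ccc(-n2c(S)nnc2Sc2nnc(-c3ccccc3)n2-c2ccccc2)cc1` share a common core and differ only in the group attached to one of its nitrogens; in a functional assay on HT-29 cells (Homo sapiens) for inhibition, read by MTT assay, with a stated time of 48 h (a higher number here means a weaker inhibitor, a lower number a stronger inhibitor), compound 1 is recorded as "not determined" (no result reported), so it offers no number to build on. Compound 2 gives 46800 nM in this assay, a high half-maximal inhibitory concentration that marks it as a weak inhibitor. Among the measured compounds shown here, as the only value shown, compound 2 stands alone, and no step between two measured compounds can be drawn from this set.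

Compound 3 `Sc1nnc(Sc2nnc(-c3ccccc3)n2-c2ccccc2)n1-c1ccc(Cl)cc1` is the next compound to be measured in this assay. It differs from compound 2 by chloro in place of ethoxy on an aromatic carbon. No comparable change has been measured in this series, so the step expected here is small, a 1.2-fold lower number from compound 2 to compound 3 (0.09 log units; within the scatter), with no confident direction and nothing beyond the usual scatter anticipated. On that basis, compound 3 is expected to give 38000 nM in this assay, within a range from 13000 nM to 110000 nM.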

Compound 3, half-maximal inhibitory concentration: 38400 nM
Beside the measured number, compound 3's estimate is 1.0-fold (0.00 log units) below it; the measured number falls inside the stated range.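

Among the compounds shown here, the first step that can be read in this assay is 4-ethoxyphenyl to 4-chlorophenyl, with chloro in place of ethoxy on an aromatic carbon para to a large group, and it comes to a 1.2-fold lower number from compound 2 to compound 3 (0.09 log units; within the scatter) for this exchange. At this position, then, the assay does not tell the two groups apart, although chloro carries fewer heavy atoms than ethoxy and no hydrogen-bond acceptor, so neither that count nor the acceptor shows any link to the number in this one pair. Nothing available explains this outcome or bears on it.

On these data alone, whether an amine, a carboxylic acid or a longer chain in place of ethoxy at this same position would bring a step beyond the scatter remains open, since a single pair of groups cannot show how far this place tolerates change. As far as these compounds go, compound 1 stands at "not determined" (no result reported), so its steps to compound 2 and compound 3 cannot be read, and what an aromatic ring on that nitrogen contributes stays open as well.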